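The compounds below may be only part of what the source reports. "The series", "measured", "known", "first", "only" and "open" are said of these compounds alone.

Only part of this small set has numbers. In a functional assay on OVCAR-3 cells (Homo sapiens) for antiproliferative activity, read by WST assay, with a stated time of 72 h, in the absence of a further agent (on this read-out higher numbers stand for weaker inhibition and lower numbers for stronger inhibition), compound 1 `CCCCCCCC/C=C\c1c(C)nc(C)c(/C=C\CCCCCCCC)c1C` has the entry "not determined" (no result reported), so it offers no figure to compare. Compound 2 `CCCCCCCCCCc1c(C)c(CCCCCCCCCC)c2[n+](c1C)CCC2` gives 600 nM, and compound 3 `CCCCCCCC/C=C\c1c(C)c(/C=C\CCCCCCCC)c2[n+](c1C)CCC2` gives 1100 nM. These two numbers lie within the scatter of each other, so the read-out does not separate compound 3 from compound 2. Compound 4 `CCCCCCCC/C=C\c1c(C)cc(C)[n+]2c1CCC2` keeps the core of compound 3 but carries hydrogen in place of dec-1-en-1-yl on an aromatic carbon, ortho to two methyl groups: hydrogen in place of dec-1-en-1-yl on an aromatic carbon. Within the data shown here, no measured pair in this assay shows this change, so the expectation rests on little. Compound 3, at 1100 nM, carries two dec-1-en-1-yl groups and compound 4 keeps one, so a weaker result, beyond the scatter, is expected in this assay. The expected change is a 3.6-fold higher number from compound 3 to compound 4 (0.56 log units; beyond the scatter). Compound 4 is estimated at 4000 nM, with an expected range of 1200 nM to 14000 nM.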

Compound 4, half-maximal inhibitory concentration: 1300 nM
Compound 4: middle estimate off by 3.1-fold (0.49 log units), on the high side, within the range that was stated.
By their numbers in this assay, from the lowest: compounds 2, 3 and 4 (each within the scatter of the next, the first and the last beyond it).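

In this assay, replacing the dec-1-en-1-yl group on this aromatic carbon, ortho to two methyl groups, with hydrogen gives a 1.2-fold higher number from compound 3 to compound 4 (0.07 log units; within the scatter), so the read-out does not separate the two compounds. Among these compounds, no earlier pair covered this change, and compounds 2 and 3 each carry two chains, so they could not show that a number of this size persists with only one dec-1-en-1-yl group in place. No measurement given here bears on the reason for this result.

Going by these compounds, it remains open whether an amine or a carboxylic acid on this aromatic carbon, or a longer chain there, would read differently from hydrogen. On these data alone, it is also open how the number would respond if the remaining dec-1-en-1-yl group of compound 4 gave way to hydrogen as well.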